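This account rests on a few compounds, and the source may have more. Where it says the series, first, only, none or still open, it means among the compounds named here.

Measured compounds:
compound 1, `COc1ccc(/C=N/NC(=O)Nc2ccc(Oc3ccnc4cc(OCCCN5CCCCC5)c(OC)cc34)c(F)c2)c(OC)c1`, 1400 nM
compound 2, `COc1cc2c(Oc3ccc(NC(=O)N/N=C/c4ccncc4)cc3F)ccnc2cc1OCCCN1CCCCC1`, 840 nM

Going by the values given here, in a functional assay on A549 cells (Homo sapiens) for cytotoxicity, read by MTT assay, with a stated time of 72 h (on this read-out lower numbers stand for stronger inhibition and higher numbers for weaker inhibition), compound 2 gives 840 nM, the lower of the two numbers, but the only step that reaches it, a 1.7-fold lower number from compound 1 to compound 2 (0.22 log units; within the scatter), is within the scatter, so the two compounds cannot be put in order on this read-out.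

Compound 3, `COc1cc2c(Oc3ccc(NC(=O)N/N=C/c4cc5ccccc5[nH]4)cc3F)ccnc2cc1OCCCN1CCCCC1`, differs from compound 2 in one place: 1H-indol-2-yl in place of pyridin-4-yl on a carbon with a double bond to nitrogen. Among the compounds with values here, the one measured step that bears on this change is the exchange of one aromatic group for another at the same carbon, a 1.7-fold lower number from compound 1 to compound 2 (0.22 log units; within the scatter), which stayed within the scatter. On that basis the step to compound 3 is expected to be small, a 1.2-fold higher number from compound 2 to compound 3 (0.08 log units; within the scatter), with no change beyond the scatter in either direction. Compound 3 is therefore estimated at 1000 nM in this assay, with a range from 300 nM to 3500 nM.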

Compound 3, half-maximal inhibitory concentration: 780 nM
The estimate for compound 3 lay 1.3-fold (0.11 log units) above the measured number; the measured number falls inside the stated range.
By their numbers in this assay, from the lowest: compounds 3, 2 and 1 (each within the scatter of the next).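

In this assay, the carbon with a double bond to nitrogen now carries a third aromatic group. 1H-indol-2-yl, which brings a five-membered aromatic ring and a hydrogen-bond donor that pyridin-4-yl lacks, gives a 1.1-fold lower number from compound 2 to compound 3 (0.03 log units; within the scatter). Set against 2,4-dimethoxyphenyl, the same group gives a 1.8-fold lower number from compound 1 to compound 3 (0.25 log units; within the scatter), so these three aromatic groups cannot be put in order at this position, and nothing available explains why the numbers stay so close.

The compounds shown leave open whether a group without an aromatic ring at this carbon, such as cyclohexyl, or an aromatic ring carrying an amine or a carboxylic acid, would move the number beyond the scatter. They also leave open whether a methyl group on the ring nitrogen of the 1H-indol-2-yl would change the number.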